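The compounds below may be only part of what the source reports. "The series", "measured", "known", "first", "only" and "open" are said of these compounds alone.

Compound 1, `Nc1nn2c(O)cc(-c3ccc(F)cc3)nc2c1[N+](=O)[O-]`: > 50 ug/mL
Compound 2, `NNCc1cc(O)n2nc(N)c([N+](=O)[O-])c2n1`: 35.2 ug/mL

In a functional assay on L929 cells (Mus musculus) for inhibition (on this read-out lower numbers stand for stronger inhibition of growth and higher numbers for weaker inhibition of growth), compound 1 gives only a limit, > 50 ug/mL, and not a number. This is the edge of what this assay reports (the limit of > 50 ug/mL in this assay, at which 1 of the 2 values shown sits), so compound 1 stands only at a limit, with no exact value. Compound 2 gives in this assay 35.2 ug/mL. Going by the values given here, the one measured step, an at least 1.4-fold lower number from compound 1 to compound 2 (0.15 log units; that floor lies within the scatter), has a floor that lies within the usual scatter, so it shows only that the number did not rise.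

Compound 3, `Nc1nn2c(O)cc(CNNCCO)nc2c1[N+](=O)[O-]`, has not yet been measured. It differs from compound 1 in one place: (((2-hydroxyethyl)amino)amino)methyl in place of 4-fluorophenyl on an aromatic carbon. The change resembles the measured one, as both replace the 4-fluorophenyl with a short chain of amino groups on the same carbon; here the chain also carries a 2-hydroxyethyl group. That single measured step therefore bears on it, and its small size suggests that the step of an at least 1.3-fold lower number from compound 1 to compound 3 (0.11 log units; that floor lies within the scatter) is expected to be modest, toward a somewhat lower number. Compound 3 is expected to give in this assay about 38 ug/mL, within 18 ug/mL to 80 ug/mL, with a real chance that only a limit is reported.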

Compound 3, concentration for 50% growth inhibition: > 50 ug/mL
Compound 3: no number, only a limit; the forecaster's own chance of this, stated with the estimate: 45%; middle value at least 1.3-fold (0.11 log units) from the limit.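

Compound 3 stops at a limit and not at a number in this assay, the same limit that compound 1 reaches: the limit of > 50 ug/mL in this assay, at which 2 of the 3 values shown sit. The step between these two compounds cannot be read, so this position on the aromatic carbon still gives no measured size for replacing 4-fluorophenyl with this longer chain. Going by these compounds alone, what is new is a look at the end of the chain: putting 2-hydroxyethyl in place of hydrogen on an amine nitrogen gives an at least 1.4-fold higher number from compound 2 to compound 3 (0.15 log units; that floor lies within the scatter), and since that floor lies within the usual scatter, it shows only that the number did not fall and that the added group brought no measurable gain in growth inhibition.

Going by these compounds, whether 2-hydroxyethyl truly weakens growth inhibition stays open, as compound 2 is the only one of the three with an exact number. Also open, on these data alone, is whether a methyl group, a longer chain such as 3-hydroxypropyl, or a carboxylic acid at the end of the chain on that amine nitrogen would give a number rather than a limit.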